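A few compounds are considered here, and "the series" means these few. Any claim that something is new, unique, unknown or untested is made for them only; others in the source may bear on it.

Measured compounds:
- Compound 1 `CNC(=O)CN1CC[C@H](n2c(Nc3ccccc3)nc3cnc(Nc4ccc(N5CCN(C)CC5)cc4)nc32)C1` — a functional assay on A-431 cells (Homo sapiens) for antiproliferative activity, read by MTT assay, with a stated time of 72 h; on this read-out lower numbers stand for stronger inhibition and higher numbers for weaker inhibition: "not determined" (no result reported)
- Compound 2 `CN1CCN(c2ccc(Nc3ncc4nc(Nc5ccccc5)n([C@@H]5CCN(C(=O)OC(C)(C)C)C5)c4n3)cc2)CC1` — "not determined" (no result reported)
- Compound 3 `CN1CCN(c2ccc(Nc3ncc4nc(Nc5ccccc5)n([C@H]5CCN(S(=O)(=O)C6CC6)C5)c4n3)cc2)CC1` — 1670 nM

The series shares one core and varies only the substituent on the saturated ring nitrogen and the configuration of the ring carbon that carries the core. Compound 1 and compound 2 carry no result, so they offer no numbers to compare. For the measured compounds named here, compound 3 therefore stands alone: in this assay compound 3 gives 1670 nM, the only figure the set provides, and no step between measured compounds can be drawn from it.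

Compound 4 `CN1CCN(c2ccc(Nc3ncc4nc(Nc5ccccc5)n([C@@H]5CCN(S(=O)(=O)C6CC6)C5)c4n3)cc2)CC1` is the partner of compound 3 in the sense that (the two compounds have the same atoms and bonds and differ only in configuration as drawn: 1 of 1 stereo elements differ; a stereocentre at a saturated ring carbon is drawn S in compound 3 and R in compound 4). As far as these compounds go, nothing in the data shows how this assay responds to a change of configuration at that carbon, so the direction of the step is unknown. Given that compound 3 gives 1670 nM, the estimate for compound 4 is 1500 nM, with a range from 300 nM to 8000 nM, which means an expected step from compound 3 to compound 4 of a 1.1-fold lower number from compound 3 to compound 4 (0.05 log units; within the scatter); the range is wide because either enantiomer could be the more active one.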

Compound 4, half-maximal inhibitory concentration: > 10000 nM
Compound 4 was reported as a limit; the forecaster's own chance of this, stated with the estimate: 10%; middle value at least 6.6-fold (0.82 log units) from the limit.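

In this assay, for the compounds shown here, the configuration of the saturated ring carbon that carries the shared core turns out to matter, which no earlier compound could show: going from S to R gives an at least 5.9-fold higher number from compound 3 to compound 4 (0.77 log units; beyond the scatter). As far as these compounds go, the value of compound 4, > 10000 nM, is a limit of the assay and not a number, so the true size of this step remains unknown, and the S configuration is favoured only within this one pair. The step can be assigned to that stereocentre alone because nothing else separates the two structures: the fact that compounds 3 and 4 differ only in the configuration as drawn

Steps involving compound 1 and compound 2 cannot be read, so the compounds shown do not reveal how the substituent on the saturated ring nitrogen influences activity in this assay, or whether either of those two substituents would match the cyclopropyl sulfonyl group of compound 3. From the compounds shown here alone, it also remains open whether the same preference for the S configuration would hold with a different group on that nitrogen, such as an acetyl group or a free amine.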